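The compounds below may be only part of what the source reports. "The series", "measured", "known", "first", "only" and "open" are said of these compounds alone.

In a functional assay on MCF7 cells (Homo sapiens) for antiproliferative activity, read by MTT assay, with a stated time of 24 h (a higher number here means a weaker inhibitor, a lower number a stronger inhibitor), three compounds with a shared core have been measured: compound 1 `O=S(=O)(c1ccc(Cl)cc1)n1c(-c2cn(-c3ccccc3)nc2-c2ccc(F)cc2)nc2ccccc21` gives 4960 nM, compound 2 `COc1ccc(S(=O)(=O)n2c(-c3cn(-c4ccccc4)nc3-c3ccc(C(F)(F)F)cc3)nc3ccccc32)cc1` gives 420 nM, and compound 3 `O=S(=O)(c1ccc(F)cc1)n1c(-c2cn(-c3ccccc3)nc2-c2ccc(C(F)(F)F)cc2)nc2ccccc21` gives 3120 nM. Compound 3 lies within the scatter of compound 1 and well above compound 2. Compound 4 `O=S(=O)(c1ccc(Cl)cc1)n1c(-c2cn(-c3ccccc3)nc2-c2ccc(C(F)(F)F)cc2)nc2ccccc21` differs from compound 3 by chloro in place of fluoro on an aromatic carbon. Going by the values given here, the only measured step, a 7.4-fold higher number from compound 2 to compound 3 (0.87 log units; beyond the scatter), replaced methoxy with fluoro, so it bears only loosely on this swap. Compound 1 also carries the (4-chlorophenyl)sulfonyl group and gives 4960 nM, which suggests no large change. The expected step in this assay is therefore small, a 1.0-fold lower number from compound 3 to compound 4 (0.02 log units; within the scatter), within the scatter. For compound 4 the estimated value is 3000 nM, with a range of 1200 nM to 7000 nM.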

Compound 4, half-maximal inhibitory concentration: 4320 nM
The estimate for compound 4 lay 1.4-fold (0.16 log units) below the measured number; the range from low to high includes it.
By their numbers in this assay, from the lowest: compound 2; then compounds 3, 4 and 1 (each within the scatter of the next).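

In this assay, chloro and fluoro at this place on the (4-chlorophenyl)sulfonyl group's ring cannot be told apart (a 1.4-fold higher number from compound 3 to compound 4 (0.14 log units; within the scatter)), whereas methoxy stands well clear of chloro (a 10-fold higher number from compound 2 to compound 4 (1.01 log units; beyond the scatter)). Trifluoromethyl in place of fluoro on the other ring also makes no readable difference (a 1.1-fold lower number from compound 1 to compound 4 (0.06 log units; within the scatter)). Nothing measured here explains these results.

As far as these compounds go, whether the low number of compound 2 is particular to methoxy remains open. An amine, a hydroxyl or a carboxylic acid at the same place could fall on either side of the gap between methoxy and the two halogens.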